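The source may report more compounds than this note shows. Statements on the series, on what has been measured and on what is new or still open speak of the compounds shown alone.

Measured compounds:
- compound 1 `O=C(CSc1nc(Nc2ccccc2)c2ccccc2n1)Nc1cccc(Cl)c1`: 12600 nM
- compound 2 `C=CC(=O)Nc1cccc(NC(=O)CSc2nc(Nc3ccccc3F)c3ccccc3n2)c1`: 9340 nM

Both compounds were tested in a functional assay on PC-3 cells (Homo sapiens) for inhibition, read by MTT assay, with a stated time of 72 h; on this read-out lower numbers stand for stronger inhibition and higher numbers for weaker inhibition. Compound 1 gives 12600 nM in this assay, and compound 2 gives 9340 nM. Compound 2 has the lower of the two numbers, but the gap to compound 1 is within the usual scatter of repeated measurements, so the two results cannot be told apart with confidence; neither compound can be called the stronger inhibitor on this evidence.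

The step of interest leads from compound 2 to compound 3 `C=CC(=O)Nc1cccc(NC(=O)CSc2nc(Nc3ccc(CC)cc3)c3ccccc3n2)c1`, which has not yet been tested in this assay. The change is 4-ethylphenyl in place of 2-fluorophenyl on a nitrogen on an aromatic ring. For the measured compounds named here, no pair of measured compounds shows this kind of change, so there is no measured step to lean on; all that is known is how compound 2 and compound 1 behave.

With nothing to suggest otherwise, the step of a 1.0-fold lower number from compound 2 to compound 3 (0.02 log units; within the scatter) is expected to stay within the scatter, in no clear direction. Compound 3 is therefore estimated at 9000 nM in this assay, in a range from 3000 nM to 27000 nM.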

Compound 3, half-maximal inhibitory concentration: 24300 nM
Compound 3: the middle estimate sits 2.7-fold (0.43 log units) below what was measured; measured number inside the range.
By their numbers in this assay, from the lowest: compounds 2, 1 and 3 (each within the scatter of the next, the first and the last beyond it).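

The exchange of 2-fluorophenyl for 4-ethylphenyl on the nitrogen gives a 2.6-fold higher number from compound 2 to compound 3 (0.42 log units; beyond the scatter) in this assay and is a modest step beyond the scatter, so what sits at this position can shift the result, here towards weaker inhibition. The two groups differ both in the substituent, fluorine against ethyl, and in where it sits on the phenyl ring, so this single step cannot show which of the two differences matters. Nothing in the data shown explains why the number rises.

A 4-fluorophenyl or a 2-ethylphenyl group on the same nitrogen would help separate the identity of the substituent from its place on the ring. On these data alone, it also remains open whether a longer chain, as in 4-butylphenyl, would push the number further in the same direction, or whether an amine, as in 4-aminophenyl, would bring it back down.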